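Compound 3: an expected clearance from two close neighbours

A few compounds are considered here, and "the series" means these few. Any claim that something is new, unique, unknown or untested is made for them only; others in the source may bear on it.

Measured in an ADME assay (liver) for metabolic stability, with Liver microsome (Rattus norvegicus) as the target, using microsomes and NADPH, with a stated time of 30 min, tested at 1 uM; on this read-out lower numbers stand for slow clearance and higher numbers for fast clearance
Compound 1 `Nc1ccc(S(=O)(=O)N2CCN(c3ncc(C(O)(C(F)(F)F)C(F)(F)F)cc3-c3ccoc3)CC2)cn1` gives 57 mL.min-1.g-1
Compound 2 `NC(=O)c1cccc(-c2cc(C(O)(C(F)(F)F)C(F)(F)F)cnc2N2CCN(S(=O)(=O)c3ccc(N)nc3)CC2)c1` gives 63 mL.min-1.g-1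

Compound 2 has the higher of the two numbers, but the gap lies within the scatter, so it holds no clear place of its own. Compound 3 `Nc1ccc(S(=O)(=O)N2CCN(c3ncc(C(O)(C(F)(F)F)C(F)(F)F)cc3-c3cccnc3)CC2)cn1` carries pyridin-3-yl in place of 3-carbamoylphenyl on an aromatic carbon. For the measured compounds named here, only one measured step bears on this change, and it touches the same place, with 3-carbamoylphenyl in place of furan-3-yl. That step is small, a 1.1-fold higher number from compound 1 to compound 2 (0.04 log units; within the scatter). One step is thin evidence, but no shift beyond the scatter is expected in this assay. The expected step is a 1.1-fold lower number from compound 2 to compound 3 (0.06 log units; within the scatter). The estimated value for compound 3 is 55 mL.min-1.g-1. The expected range runs from 30 mL.min-1.g-1 to 100 mL.min-1.g-1.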

Compound 3, intrinsic clearance in microsomes: 20 mL.min-1.g-1
The estimate for compound 3 lay 2.8-fold (0.44 log units) above the measured number; the measured number lies below the stated range.
By their numbers in this assay, from the lowest: compound 3; then compounds 1 and 2 (each within the scatter of the next).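

In this assay, the group on this aromatic carbon proved able to shift clearance beyond the scatter: pyridin-3-yl gave a 3.2-fold lower number from compound 2 to compound 3 (0.50 log units; beyond the scatter) against 3-carbamoylphenyl and a 2.9-fold lower number from compound 1 to compound 3 (0.45 log units; beyond the scatter) against furan-3-yl. For the compounds shown here, the earlier compounds could not show this, since furan-3-yl and 3-carbamoylphenyl lie within the scatter of each other, and pyridin-3-yl is the only one of the three groups here that stands apart. Nothing measured here accounts for this difference.

The compounds shown leave open whether a plain phenyl, a pyridin-4-yl or a pyrimidin-5-yl group at this place would fall with compound 3 or stay with compound 1 and compound 2. On these data alone, it also remains open whether pyridin-3-yl would keep this lower number if a carboxylic acid replaced the 2,2,2-trifluoro-1-hydroxy-1-(trifluoromethyl)ethyl group.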